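Replacing the pyridine arm in a TRPM8 agonist series

A few compounds are considered here, and "the series" means these few. Any claim that something is new, unique, unknown or untested is made for them only; others in the source may bear on it.

Compound 1 `CCN(Cc1cccnc1)C(=O)COc1ccc(C)cc1` stands at the high end of the three measurements: in an assay on HEK293 cells for agonist activity at transient receptor potential cation channel subfamily M member 8 (Homo sapiens), read by fluorescence and calcium flux, with a stated time of 15 min (a higher number here means that more compound is needed for the effect, a lower number that less compound is needed), compound 1 gives 15400 nM. Compound 3 `CCN(Cc1cccs1)C(=O)COc1cccc(C)c1` gives 97 nM in this assay, and compound 2 `COc1ccc2oc(C(=O)N(Cc3cccs3)c3ccn[nH]3)cc2c1` gives 1.1 nM, so compound 1 needs far more material than either. Compound 4 `CCN(Cc1ccc(C)s1)C(=O)COc1ccc(C)cc1` is built from compound 1 by one change: 5-methylthiophen-2-yl in place of pyridin-3-yl on a saturated chain carbon bound to an amide-type nitrogen. Among the compounds with values here, no measured pair isolates this change; compound 3 carries a thiophene arm but also differs from compound 1 elsewhere, so it offers only a hint. Compound 4 is expected to need much less material than compound 1, a step of a 31-fold lower number from compound 1 to compound 4 (1.49 log units; beyond the scatter), with the estimate for compound 4 set at 500 nM and a range from 60 nM to 4000 nM.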

Compound 4, half-maximal effective concentration: 178 nM
Beside the measured number, compound 4's estimate is 2.8-fold (0.45 log units) above it, within the range that was stated.
By their numbers in this assay, from the lowest: compound 2; then compounds 3 and 4 (each within the scatter of the next); then compound 1.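

Within the data shown here, for the first time, one pair isolates this position: in this assay, with the rest of the molecule held constant, 5-methylthiophen-2-yl in place of pyridin-3-yl gives an 87-fold lower number from compound 1 to compound 4 (1.94 log units; beyond the scatter). The group on this saturated chain carbon bound to an amide-type nitrogen can therefore shift the number substantially on its own. Nothing available explains why this change has such an effect. The compounds shown leave open whether the step belongs to the thiophene ring or to its methyl, and how a phenyl or 5-ethylthiophen-2-yl group would behave here.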